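This account rests on a few compounds, and the source may have more. Where it says the series, first, only, none or still open, it means among the compounds named here.

Measured in a functional assay on DU-145 cells (Homo sapiens) for cytotoxicity, read by MTT assay; on this read-out higher numbers stand for weaker inhibition and lower numbers for stronger inhibition:
- compound 1 `CCCC(CC(=O)O[C@H](CC=C(C)C)C1=CC(=O)c2c(O)ccc(O)c2C1=O)OC(C)=O`: 55700 nM
- compound 2 `CC[C@@](C)(O)CC(=O)O[C@H](CC=C(C)C)C1=CC(=O)c2c(O)ccc(O)c2C1=O`: 12700 nM
- compound 3 `CC(C)=CC[C@@H](OC(=O)C1CCCO1)C1=CC(=O)c2c(O)ccc(O)c2C1=O`: 10500 nM

Compound 3, at 10500 nM, cannot be told apart from compound 2, while compound 1 sits clearly higher. Compound 4 `CCCCC(C)(O)CC(=O)O[C@H](CC=C(C)C)C1=CC(=O)c2c(O)ccc(O)c2C1=O` brings this change: 2-hydroxy-2-methylhexyl in place of oxolan-2-yl on a carbonyl carbon. In words, 2-hydroxy-2-methylhexyl replaces oxolan-2-yl on a carbonyl carbon. The closest guide is a 1.2-fold lower number from compound 2 to compound 3 (0.08 log units; within the scatter), where 2-hydroxy-2-methylbutyl, differing from the entering group only in butyl for hexyl, gave way to oxolan-2-yl. The larger steps, a 4.4-fold lower number from compound 1 to compound 2 (0.64 log units; beyond the scatter) and a 5.3-fold lower number from compound 1 to compound 3 (0.72 log units; beyond the scatter), both start from the acetoxy chain of compound 1, which is absent here. In this assay the expected result is therefore a 1.1-fold higher number from compound 3 to compound 4 (0.06 log units; within the scatter), no step beyond the scatter. Compound 4 is estimated at 12000 nM, with an expected range of 5000 nM to 30000 nM.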

Compound 4, half-maximal inhibitory concentration: 76500 nM
Beside the measured number, compound 4's estimate is 6.4-fold (0.80 log units) below it; measured number outside the range, above it.
By their numbers in this assay, from the lowest: compounds 3 and 2 (each within the scatter of the next); then compounds 1 and 4 (each within the scatter of the next).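

Chain length alone matters at this position: in this assay, going from 1-hydroxy-1-methylpropyl to 1-hydroxy-1-methylpentyl gives a clear rise (a 6.0-fold higher number from compound 2 to compound 4 (0.78 log units; beyond the scatter)), although the shorter hydroxy chain could not be told apart from oxolan-2-yl. The longer chain also separates from oxolan-2-yl (a 7.3-fold higher number from compound 3 to compound 4 (0.86 log units; beyond the scatter)), yet cannot be told apart from the acetoxy chain (a 1.4-fold higher number from compound 1 to compound 4 (0.14 log units; within the scatter)). No measurement here explains the rise. Still open, going by these compounds, is whether a 2-hydroxy-2-methyloctyl chain would raise the number further, and whether an amine in place of the hydroxy group would change it.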